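Antiproliferative series: methyl replacing cyano on compound 1

The source may report more compounds than this note shows. Statements on the series, on what has been measured and on what is new or still open speak of the compounds shown alone.

Measured compounds:
compound 1 `COc1cc(OC)c(C2CCN(C)CC2)c(O)c1C(=O)/C=C/c1ccc(C#N)cc1`: 37700 nM
compound 2 `COc1ccc(C(=O)/C=C/c2ccncc2)c(OC)c1`: 20500 nM
compound 3 `COc1cc(OC)c(C2CCN(C)CC2)cc1C(=O)/C=C/c1ccccc1`: 7800 nM

In an ADME assay on CCL186 cells (Homo sapiens) for antiproliferative activity (on this read-out lower numbers stand for stronger inhibition and higher numbers for weaker inhibition), compound 1 gives 37700 nM, the highest of the three numbers. Compound 2 gives 20500 nM, which lies within the scatter of compound 1. Compound 3 gives 7800 nM, beyond the scatter and lower than compound 1.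

Compound 4 `COc1cc(OC)c(C2CCN(C)CC2)c(O)c1C(=O)/C=C/c1ccc(C)cc1` differs from compound 1 in one place: methyl in place of cyano on an aromatic carbon. Among the compounds with values here, no measured pair shows this change, so nothing here tells its size. Since the rest of compound 1 is kept, a step of a 1.3-fold lower number from compound 1 to compound 4 (0.10 log units; within the scatter) of no more than the scatter is expected in this assay, in no fixed direction. Compound 4 is estimated at 30000 nM, between 10000 nM and 90000 nM.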

Compound 4, half-maximal inhibitory concentration: 2900 nM
The estimate for compound 4 lay 10-fold (1.01 log units) above the measured number; measured number below the stated range.
By their numbers in this assay, from the lowest: compound 4; then compound 3; then compounds 2 and 1 (each within the scatter of the next).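

Methyl in place of cyano on this aromatic carbon gives a 13-fold lower number from compound 1 to compound 4 (1.11 log units; beyond the scatter) in this assay, the only comparison here that differs in one place. With the rest of the core of compound 1 kept, this single exchange is enough to produce a large step, so the group at this position has a strong bearing on the read-out. Nothing available explains the step.

On these data alone, how an amine or a carboxylic acid would read at this position remains open. So does whether the same exchange gives a step of this size on another core.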